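Swapping Hydroxy for Chloro: Expected Cell Tolerance

The source may report more compounds than this note shows. Statements on the series, on what has been measured and on what is new or still open speak of the compounds shown alone.

Compound 2 `O=C(/C=C/c1cc2ccccc2[nH]c1=O)c1ccc(O)cc1` is compared with compound 3 `O=C(/C=C/c1cc2ccccc2[nH]c1=O)c1ccc(Cl)cc1` in an ADME assay on T47D cells (Homo sapiens) for cytotoxicity, read by sulforhodamine B assay, with a stated time of 24 h; a lower number here means that less compound is tolerated, a higher number that more compound is tolerated. Among the compounds with values here, compound 2 gives 79600 nM, the only plain number available. Compound 1 `COc1ccc(C(=O)/C=C/c2cc3ccccc3[nH]c2=O)cc1` reaches only a limit of the assay, > 100000 nM. That limit is the limit of > 100000 nM in this assay, at which 1 of the 2 values shown sits. The step of an at least 1.2-fold lower number from compound 1 to compound 2 (0.09 log units; that floor lies within the scatter) concerns hydrogen in place of methyl on an oxygen on an aromatic ring, so it does not bear on the change now considered, (chloro in place of hydroxy on an aromatic carbon). Within the data shown here, no measured step covers chloro in place of hydroxy, so compound 3 is expected to show a step of a 1.4-fold lower number from compound 2 to compound 3 (0.16 log units; within the scatter) that does not clearly exceed the scatter. Compound 3 is estimated at 55000 nM, between 20000 nM and 150000 nM.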

Compound 3, concentration lethal to 50% of the cells: > 100000 nM
Compound 3 gave a limit, no number; the forecaster's own chance of this, stated with the estimate: 30%; at least 1.8-fold (0.25 log units) between middle value and limit.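

Compound 3 reaches a limit of this assay, not a number. Chloro in place of hydroxy gives an at least 1.2-fold higher number from compound 2 to compound 3 (0.09 log units; that floor lies within the scatter), so this place on the ring accepts a group with no hydrogen-bond donor with no sign of a lower number, and the true step may exceed that floor. The step between compound 1 and compound 3 cannot be read, because both values are limits: the limit of > 100000 nM in this assay, at which 2 of the 3 values shown sit.

Going by these compounds, how large the step from hydroxy to chloro really is remains open. So does whether an amine or a carboxylic acid at this place would give a plain number.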